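A few compounds are considered here, and "the series" means these few. Any claim that something is new, unique, unknown or untested is made for them only; others in the source may bear on it.

For the measured compounds named here, in a physicochemical assay for lipophilicity (a higher number here means a more lipophilic compound, a lower number a more polar compound), three compounds have numbers so far. Compound 1 `OC(c1ccccc1)c1c(C(F)(F)F)nc2ccc(Br)cc2c1Br` reads 6.26 on this scale, compound 2 `COc1ccccc1NC(=S)Nc1ccc2nc(Oc3ccc(F)cc3C(C)O)c(Cc3ccccc3)cc2c1` reads 7.86 and compound 3 `CC(c1cc(F)ccc1Oc1nc2ccc(-n3cc(-c4ccccc4)nn3)cc2cc1Cc1ccccc1)n1ccnc1` reads 7.91 on the same scale. Compound 2 therefore lies within the usual scatter of compound 3, while it stands well above compound 1, beyond the scatter.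

Compound 4 `COc1ccccc1NC(=O)Nc1ccc2nc(Oc3ccc(F)cc3C(C)O)c(Cc3ccccc3)cc2c1` still awaits its number. It differs from compound 2 in one place, and a group of 11 heavy atoms (8 carbon, 1 nitrogen, 2 oxygen; one six-membered aromatic ring of carbon only) in place of a group of 11 heavy atoms (8 carbon, 1 nitrogen, 1 oxygen, 1 sulfur; one six-membered aromatic ring of carbon only), on a nitrogen on an aromatic ring is the change there. On a nitrogen on an aromatic ring, (2-methoxyphenyl)carbamoyl enters, and a group holding sulfur where the new group holds oxygen leaves.

Going by the values given here, no two measured compounds show this change, so there is no direct yardstick, and the expectation rests on the structural change alone. A modest fall in this assay is expected, probably somewhat larger than the scatter. The estimated step runs a number 0.56 log units lower from compound 2 to compound 4 (beyond the scatter) on this reasoning. Compound 4 is expected to read 7.3 with an estimated range from 6.8 to 7.7 once it is measured.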

Compound 4, partition coefficient: 6.72
The estimate for compound 4 lay 0.58 log units above the measured number; measured number below the stated range.
By their numbers in this assay, from the lowest: compound 1; then compound 4; then compounds 2 and 3 (each within the scatter of the next).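

In this assay, for the compounds shown here, exchanging one sulfur atom for one oxygen atom in the group on this aromatic nitrogen gives a number 1.14 log units lower from compound 2 to compound 4 (beyond the scatter) and so provides the first step here that isolates a single change. The two groups match in heavy-atom count, in their carbon-only aromatic ring and in their counts of hydrogen-bond donors and acceptors, so those counts do not separate them, yet this one-atom exchange alone moves the reading by a large step. No measurement shown here explains the size of this step.

Going by these compounds alone, whether the same exchange gives a step of similar size in another compound stays open, as this pair is the only example. Also open, from the compounds shown here alone, is how the reading would respond if an acetyl group or a plain phenyl carbamoyl group stood on this nitrogen.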